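Cyclopropyl to pyridin-4-yl on the amide nitrogen

The compounds below may be only part of what the source reports. "The series", "measured", "known", "first", "only" and "open" are said of these compounds alone.

Compound 3 `O=C(/C=C/[C@H]1C[C@@H](O)[C@@H](O)C1)NC1CC1` is one of three amides on a shared core examined in an ADME assay on S2 cells (Drosophila melanogaster) for cytotoxicity, read by MTT assay; a lower number here means that less compound is needed, a higher number that more compound is needed for the effect. In this assay compound 3 gives > 250000 nM, which is a limit of the assay and not a number. Compound 1 `CNC(=O)/C=C/[C@H]1C[C@@H](O)[C@@H](O)C1` gives > 250000 nM in this assay, again a limit. Compound 2 `CCNC(=O)/C=C/[C@H]1C[C@@H](O)[C@@H](O)C1` gives > 250000 nM in this assay, also a limit. The steps a step that the two limits leave unreadable from compound 1 to compound 2, a step that the two limits leave unreadable from compound 1 to compound 3 and a step that the two limits leave unreadable from compound 2 to compound 3 cannot be sized because of the limit of > 250000 nM in this assay, at which 3 of the 3 values shown sit.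

Compound 4 `O=C(/C=C/[C@H]1C[C@@H](O)[C@@H](O)C1)Nc1ccncc1` differs from compound 3 by pyridin-4-yl in place of cyclopropyl on an amide-type nitrogen. Going by the values given here, none of the measured steps carries a readable size that would bear on this change; each of the three simply stays at the limit. For compound 4 a step of a number no higher from compound 3 to compound 4 (the limit leaves the size open) is expected, that is, nothing beyond the scatter. The value of compound 4 in this assay is estimated at 250000 nM, within 100000 nM to 1000000 nM, and is expected most likely to come back once more as a limit rather than a number.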

Compound 4, half-maximal effective concentration: > 200000 nM
Compound 4 was reported as a limit (the forecaster's own chance of this, stated with the estimate: 85%); the middle value is on the limit's open side.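

In this assay compound 4 gives > 200000 nM, a limit of the assay and not a number. Its steps from compound 1, compound 2 and compound 3 cannot be read. Open remains whether any of these four amide groups differs from another in this read-out, as all four values are limits.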